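A Chain Change from Compound 1 to Compound 4

The compounds below may be only part of what the source reports. "The series", "measured", "known", "first", "only" and "open" are said of these compounds alone.

Among the measured compounds shown here, in a functional assay on PC-3 cells (Homo sapiens) for inhibition, read by colorimetric assay and MTT assay, with a stated time of 72 h (on this read-out higher numbers stand for weaker inhibition and lower numbers for stronger inhibition), compound 1 (`C=CCCCCOc1ccccc1-c1cnc(OCCC=C)n1C`) gives 19000 nM, the lowest of the three numbers measured so far. Compound 2 (`C=CCCCCOc1ccc(OC)cc1-c1cnc(OCCC=C)n1C`) gives 43000 nM, and compound 3 (`C=CCCCCOc1ccc(F)cc1-c1cnc(OCCC=C)n1C`) gives 52000 nM. Compound 4 (`C=CCCCCOc1ccccc1-c1cnc(OCCOCC=C)n1C`) has not yet been measured. It differs from compound 1 in one place: allyloxy stands in place of vinyl on a saturated chain carbon, two bonds along the chain from an oxygen on an aromatic ring (allyloxy in place of vinyl on a saturated chain carbon, two bonds along the chain from an oxygen on an aromatic ring). Seen one bond further out, (but-3-en-1-yl)oxy becomes 2-(allyloxy)ethoxy.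

For the measured compounds named here, only two measured steps start from compound 1, and both are modest: methoxy in place of hydrogen gives a 2.3-fold higher number from compound 1 to compound 2 (0.35 log units; beyond the scatter), and fluoro in place of hydrogen gives a 2.7-fold higher number from compound 1 to compound 3 (0.44 log units; beyond the scatter). Between those two products, the difference is small, a 1.2-fold higher number from compound 2 to compound 3 (0.08 log units; within the scatter). Going by the values given here, both changes sit on an aromatic carbon, so no measured step touches this chain, and they offer only a loose guide. Since both raised the number, a similarly modest rise is expected here, with real uncertainty about its size. The expected step is a 1.7-fold higher number from compound 1 to compound 4 (0.23 log units; within the scatter). For compound 4, the estimated value is 32000 nM, with an expected range from 11000 nM to 80000 nM.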

Compound 4, half-maximal inhibitory concentration: 36000 nM
Beside the measured number, compound 4's estimate is 1.1-fold (0.05 log units) below it, within the range that was stated.
By their numbers in this assay, from the lowest: compounds 1, 4, 2 and 3 (each within the scatter of the next, the first and the last beyond it).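

In this assay the chain tolerates this change: putting allyloxy in place of vinyl gives a 1.9-fold higher number from compound 1 to compound 4 (0.28 log units; within the scatter), so the result cannot be told apart from compound 1 with confidence. Among the compounds shown here, this is the first measured change on the chain rather than on an aromatic carbon, and it shows that a group of 4 heavy atoms, one of them oxygen and counted as 1 hydrogen-bond acceptor, can replace a vinyl group of 2 heavy atoms at this place without a step beyond the usual scatter, unlike the two substitutions on the aromatic carbon that started from compound 1. No supporting measurement bears on why the number stays so close, so the result describes what happens but offers no explanation.

The added oxygen and the added length arrive together in compound 4, and an all-carbon chain of the same length would be needed to tell their contributions apart. Also open, on these data alone, is how this place would respond to a clearly different group, such as an amine, a carboxylic acid or a much longer chain.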